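This account rests on a few compounds, and the source may have more. Where it says the series, first, only, none or still open, it means among the compounds named here.

Compound 1 `OC[C@H]1O[C@@H](n2cnc3c(NCc4ccccc4Cl)ncnc32)[C@H](O)[C@@H]1O` carries a 2-chlorobenzyl group on a saturated chain carbon bound to a nitrogen on an aromatic ring of the shared core. In an ADME assay on NIH3T3 cells (Mus musculus) for cytotoxicity, with a stated time of 72 h (a lower number here means a stronger inhibitor, a higher number a weaker inhibitor), compound 1 gives > 166000 nM, which is a limit of the assay rather than a measured number. Compound 2 `OC[C@H]1O[C@@H](n2cnc3c(NCc4ccccc4Br)ncnc32)[C@H](O)[C@@H]1O` has bromo in place of chloro on an aromatic carbon; in this assay compound 2 gives > 166000 nM, again a limit. The step that the two limits leave unreadable from compound 1 to compound 2 cannot be read because the limit of > 166000 nM in this assay, at which 2 of the 3 values shown sit, hides whatever lies beyond it. Compound 3 `OC[C@H]1O[C@@H](n2cnc3c(NCc4c(F)ccc(F)c4F)ncnc32)[C@H](O)[C@@H]1O` has "not determined" (no result reported) in this assay, so it adds nothing to the picture. Compound 4 `OC[C@H]1O[C@@H](n2cnc3c(NCc4ccc(F)c(Cl)c4)ncnc32)[C@H](O)[C@@H]1O` differs from compound 1 as follows: 3-chloro-4-fluorophenyl in place of 2-chlorophenyl on a saturated chain carbon bound to a nitrogen on an aromatic ring. Among the compounds with values here, no measured step speaks directly to this change; the only comparable pair, compound 1 and compound 2, yields nothing but limits. With every number on hand resting at the limit of > 166000 nM in this assay, at which 2 of the 3 values shown sit, the expectation is that compound 4 also shows no measurable effect within the tested range, so the step that the limit leaves unreadable from compound 1 to compound 4 is estimated to be none beyond the scatter. Compound 4 is therefore estimated at 170000 nM, with a range from 80000 nM to 400000 nM, and most likely reported once more only as a limit.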

Compound 4, half-maximal inhibitory concentration: > 166000 nM
Compound 4 ended at the assay's limit; the forecaster's own chance of this, stated with the estimate: 85%; the middle value lies beyond the limit too.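

In this assay compound 4 gives > 166000 nM, again a limit of the assay and not a number. No step among compound 1, compound 2 and compound 4 can be read, because all three rest at the same limit: the limit of > 166000 nM in this assay, at which 3 of the 4 values shown sit.

The compounds shown leave open whether these three differ from one another at all in this assay.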